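Chloro for methoxy on the hexyl-linked arylpiperazine

The source may report more compounds than this note shows. Statements on the series, on what has been measured and on what is new or still open speak of the compounds shown alone.

Three compounds of this series have numbers in an assay on cell membranes for binding affinity to Adrenergic receptor alpha-1 (Rattus norvegicus), read by radioligand binding; on this read-out lower numbers stand for stronger inhibition and higher numbers for weaker inhibition. Compound 1 `COc1ccccc1N1CCN(CCn2ncc(N3CCN(C(=O)c4ccco4)CC3)c(Cl)c2=O)CC1` gives 33 nM. Compound 2 `O=C(c1ccco1)N1CCN(c2ccc(=O)n(CCN3CCN(c4ccccc4Cl)CC3)n2)CC1` carries a chlorophenyl instead of a methoxyphenyl and differs from compound 1 in its core as well; in this assay compound 2 gives 34 nM. Compound 3 `COc1ccccc1N1CCN(CCCCCCn2nc(N3CCN(C(=O)c4ccco4)CC3)ccc2=O)CC1`, with the six-carbon chain in place of the two-carbon chain, gives 17.8 nM. Among these three numbers compound 3 sits at the small end, but its gaps to compound 1 and to compound 2 both fall within the usual scatter, so no ordering among the three can be claimed.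

Compound 4 `O=C(c1ccco1)N1CCN(c2ccc(=O)n(CCCCCCN3CCN(c4ccccc4Cl)CC3)n2)CC1` has not yet been measured. Relative to compound 3 the change is chloro in place of methoxy on an aromatic carbon. Whether this exchange shifts the number is not settled by any clean pair here, since compound 1 and compound 2 differ in more than one place; what those two show, however, is a pair of numbers that lie within the scatter of each other. On that basis the step from compound 3 to compound 4 is expected to stay within the scatter, with no direction favoured, which is what a 1.1-fold higher number from compound 3 to compound 4 (0.05 log units; within the scatter) expresses. For compound 4 in this assay the estimate is 20 nM, with a range from 8 nM to 50 nM.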

Compound 4, inhibition constant: 5.9 nM
The estimate for compound 4 lay 3.4-fold (0.53 log units) above the measured number, and the stated range ends above it.
By their numbers in this assay, from the lowest: compound 4; then compounds 3, 1 and 2 (each within the scatter of the next).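

In this assay the exchange of 2-methoxyphenyl for 2-chlorophenyl on the hexyl-linked arylpiperazine gives a 3.0-fold lower number from compound 3 to compound 4 (0.48 log units; beyond the scatter) as a modest step beyond the scatter. Within the data shown here, this is the first pair to isolate the exchange, which compounds 1 and 2 could not do with their differences in more than one place, and it shows that the number responds to the change on this aromatic carbon, ortho to a large group, where chloro with one heavy atom and no hydrogen-bond acceptor replaces methoxy with two heavy atoms and one hydrogen-bond acceptor. No measurement at hand gives a reason for the step, which stands as an observation on this single pair.

Among these compounds, whether the exchange gives a step of similar size and the same direction on the two-carbon chain of compound 2 remains open, as the hexyl pair is the only clean reading of it. Also open, as far as these compounds go, is how fluoro, bromo, methyl or trifluoromethyl would read on the same aromatic carbon, and whether a chain longer than hexyl would keep the number of compound 4.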